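This account rests on a few compounds, and the source may have more. Where it says the series, first, only, none or still open, it means among the compounds named here.

Three ureas built on a shared core have been tested in a functional assay on BaF3 cells (Mus musculus) for inhibition, read by MTT assay, with a stated time of 3 days; on this read-out higher numbers stand for weaker inhibition of growth and lower numbers for stronger inhibition of growth. Compound 1 (`COc1ccc(NC(=O)Nc2ccc(Nc3ncnc4c3OCCN4)cc2)cc1`) gives > 10000 nM, which is a limit of the assay and not a number. Compound 2 (`CC(C)(C)c1csc(NC(=O)Nc2ccc(Nc3ncnc4c3OCCN4)cc2)n1`) gives > 10000 nM, again a limit. Compound 3 (`CC(C)(C)c1cc(NC(=O)Nc2ccc(Nc3ncnc4c3OCCN4)nc2)no1`) gives > 10000 nM, also a limit. Compound 3 therefore has no exact value, and the whole set rests at the limit of > 10000 nM in this assay, at which 3 of the 3 values shown sit.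

Compound 4 (`Cc1nc(Nc2ncnc3c2OCCN3)ccc1NC(=O)Nc1cc(C(C)(C)C)on1`) is compound 3 with one small edit: methyl in place of hydrogen on an aromatic carbon. In words, a methyl takes the place of a hydrogen on an aromatic carbon, next to the ring nitrogen.

Going by the values given here, the only measured single change is a step that the two limits leave unreadable from compound 1 to compound 2. Among the compounds with values here, it concerns a different part of the molecule and gives no size to carry over, so no measured step speaks directly to this methyl. With so small an edit and no sign of growth inhibition in the set so far, no clear gain is expected in this assay, and the most likely report for compound 4 is the same limit again. The expected change is a number no higher from compound 3 to compound 4 (the limit leaves the size open), and it may not be readable at all. For compound 4 the estimate is 10000 nM, with an expected range from 2500 nM to 20000 nM.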

Compound 4, concentration for 50% growth inhibition: > 10000 nM
Compound 4: no number, only a limit (the forecaster's own chance of this, stated with the estimate: 70%); the middle value lies on the limit itself.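

In this assay compound 4 gives > 10000 nM, which is a limit and not a number. Compound 3 also rests on a limit, so the step from compound 3 to compound 4 cannot be read. The compounds shown leave open whether methyl in place of hydrogen has any effect on growth inhibition, with every result resting on the same limit: the limit of > 10000 nM in this assay, at which 4 of the 4 values shown sit.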